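This account rests on a few compounds, and the source may have more. Where it says the series, first, only, none or still open, it means among the compounds named here.

In a functional assay on MIA PaCa-2 cells (Homo sapiens) for inhibition, read by MTT assay, with a stated time of 72 h, tested at 50 uM (a lower number here means less inhibition of growth, a higher number more inhibition of growth at the concentration tested), compound 1 (`C=CCc1cc(O)c(O)c(CN2CCC(CCO)CC2)c1`) reaches 71.8% and compound 2 (`C=CCc1ccc(OCc2cn(-c3ccccc3Cl)nn2)c(O)c1`) reaches 57.7% so that compound 2 holds the lower of the two numbers, with a gap beyond the scatter. These two compounds differ in more than one place, so their gap cannot be read as the effect of any single change. Compound 3 (`C=CCc1ccc(OCc2cn(-c3ccccc3CO)nn2)c(O)c1`) differs from compound 2 in one place: hydroxymethyl stands in place of chloro on an aromatic carbon, ortho to a large group (hydroxymethyl in place of chloro on an aromatic carbon), which turns 2-chlorophenyl into 2-(hydroxymethyl)phenyl. For the measured compounds named here, no measured step shows how such a swap plays out, so the expectation rests only on compound 2 at 57.7% and on the change itself. A modest fall in this assay is expected, of a size that may well stay within the scatter. The expected move is a number 7.7 percentage points lower from compound 2 to compound 3 (within the scatter) on this estimate. For compound 3 the estimate is 50% within an expected range of 32% to 68% at the tested concentration.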

Compound 3, percent growth inhibition at one concentration: 52.1%
Compound 3: middle estimate off by 2.1 percentage points, on the low side; measured number inside the range.
By their numbers in this assay, from the lowest: compounds 3 and 2 (each within the scatter of the next); then compound 1.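

In this assay, for the compounds shown here, putting hydroxymethyl in place of chloro on an aromatic carbon, ortho to a large group, gives a number 5.6 percentage points lower from compound 2 to compound 3 (within the scatter) as the only measured step at this position. The step shows that 2-(hydroxymethyl)phenyl, which carries a hydrogen-bond donor and a hydrogen-bond acceptor that chloro lacks, leaves the growth inhibition at the tested concentration indistinguishable from that seen with 2-chlorophenyl. Nothing available explains this outcome in terms of any property of either group.

On these data alone, whether an amine, a carboxylic acid or a longer chain at this same position would move the number beyond the scatter remains open, as does whether anything other than the swap of chloro for hydroxymethyl would behave the same way on the shared core. Compound 1 differs from both compound 2 and compound 3 in more than one place, so the compounds shown do not reveal which of its features goes with its higher number.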